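Removing the Side Chain from Compound 3

This account rests on a few compounds, and the source may have more. Where it says the series, first, only, none or still open, it means among the compounds named here.

Of the compounds shown here, three sharing one core have been tested in a toxicity assay on L02 cells (Homo sapiens) for cytotoxicity, read by MTT assay, with a stated time of 72 h; a higher number here means a weaker inhibitor, a lower number a stronger inhibitor. Compound 1 (`O=C1c2c[n+]([O-])c3ccccc3c2C(=O)c2c1c1ccccc1n2CCN1CCCC1`) gives 930 nM, compound 2 (`O=C1c2c[n+]([O-])c3ccccc3c2C(=O)c2c1c1ccccc1n2CCCCN1CCCCC1`) gives 610 nM, and compound 3 (`CN1CCN(CCCCCn2c3c(c4ccccc42)C(=O)c2c[n+]([O-])c4ccccc4c2C3=O)CC1`) gives 1640 nM. Compound 3 therefore stands close to one neighbour and apart from the other, as the two comparisons show: a 1.8-fold higher number from compound 1 to compound 3 (0.25 log units; within the scatter) and a 2.7-fold higher number from compound 2 to compound 3 (0.43 log units; beyond the scatter).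

Compound 4 (`O=C1c2c[n+]([O-])c3ccccc3c2C(=O)c2[nH]c3ccccc3c21`) carries hydrogen in place of 5-(4-methylpiperazin-1-yl)pentyl on an aromatic nitrogen. The measured steps only swap one side chain for another. Besides the two above, the third is a 1.5-fold lower number from compound 1 to compound 2 (0.18 log units; within the scatter). All three are small, but none removes the chain altogether, so they guide this change only loosely. The best expectation in this assay is no clear step beyond the scatter, with wide uncertainty in either direction. The expected step is a 1.2-fold higher number from compound 3 to compound 4 (0.09 log units; within the scatter). For compound 4 the estimated value is 2000 nM, with an expected range of 500 nM to 8000 nM.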

Compound 4, half-maximal inhibitory concentration: 400 nM
Compound 4: middle estimate off by 5.0-fold (0.70 log units), on the high side; measured number outside the range, below it.
By their numbers in this assay, from the lowest: compounds 4, 2, 1 and 3 (each within the scatter of the next, the first and the last beyond it).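

In this assay taking the whole side chain off the aromatic nitrogen gives a 4.1-fold lower number from compound 3 to compound 4 (0.61 log units; beyond the scatter) and a 2.3-fold lower number from compound 1 to compound 4 (0.37 log units; beyond the scatter) and so shows that the shared core, with only hydrogen on that nitrogen, keeps this cytotoxicity without any chain. Removing 4-(piperidin-1-yl)butyl gives a 1.5-fold lower number from compound 2 to compound 4 (0.18 log units; within the scatter) and so the outcome depends on which chain leaves, and no chain shown gives a number clearly lower than the chain-free compound 4. Nothing measured here explains this difference between the chains.

From the compounds shown here alone, whether a small methyl on this nitrogen, or a chain ending in a primary amine or a carboxylic acid, would behave like compound 4 or like compound 3 stays open. The three chains also differ in length and end ring at once, leaving the share of each unresolved.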